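The compounds below may be only part of what the source reports. "The series", "measured", "known", "first", "only" and "open" are said of these compounds alone.

Measured compounds:
Compound 1 `Cc1ccccc1Nc1nc(C)c(C(=O)/C=C/c2ccc(Cl)cc2)s1` gives > 25000 nM in a functional assay on Bel-7402 cells (Homo sapiens) for cytotoxicity, read by MTT assay; on this read-out lower numbers stand for stronger inhibition and higher numbers for weaker inhibition; this value is a limit of the assay, not a number.
Compound 2 `COc1cc(/C=C/C(=O)c2sc(Nc3cccc(Cl)c3)nc2C)cc(OC)c1OC` gives 14000 nM in this assay.

Within the data shown here, compound 2 stands as the only compound with a number in this assay; the other value shown is the limit of > 25000 nM in this assay, at which 1 of the 2 values shown sits, and compound 1 sits at that limit. Among the measured compounds shown here, compound 1 and compound 2 differ in more than one place, so their two values show only that compound 2 gives a number where compound 1 gives a limit.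

Compound 3 `COc1cc(/C=C/C(=O)c2sc(Nc3ccccc3C)nc2C)cc(OC)c1OC` has not yet been measured in this assay. It differs from compound 2 by one change, (2-methylphenyl in place of 3-chlorophenyl on a nitrogen on an aromatic ring), which is 2-methylphenyl in place of 3-chlorophenyl on a nitrogen on an aromatic ring. The group that enters is the same one that compound 1 carries at that nitrogen.

With compound 2 already weak and compound 1 at the limit, the step from compound 2 to compound 3 is expected to go toward weaker inhibition, though perhaps not beyond the scatter: a 1.6-fold higher number from compound 2 to compound 3 (0.20 log units; within the scatter). Compound 3 is therefore estimated at 22000 nM in this assay, with a range from 8000 nM to 60000 nM, and a real chance that only a limit is reported.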

Compound 3, half-maximal inhibitory concentration: 10300 nM
Compound 3: the middle estimate sits 2.1-fold (0.33 log units) above what was measured; measured number inside the range.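

In this assay, placing 2-methylphenyl on the nitrogen in place of 3-chlorophenyl gives a 1.4-fold lower number from compound 2 to compound 3 (0.13 log units; within the scatter), so this single change has no readable effect on the number at this position. Compound 3 carries the same 2-methylphenyl group as compound 1 and still gives a number, so that group does not by itself go with a result at the limit. Compound 1 gives a limit of the assay and not a number: the limit of > 25000 nM in this assay, at which 1 of the 3 values shown sits.

The one step shown changes both the substituent and where it sits on the ring, so the contributions of the two cannot be separated, and a 2-chlorophenyl or a 3-methylphenyl group on this nitrogen would be needed to tell them apart. Going by these compounds, it also remains open whether any other group here, such as a cyclohexyl ring or a phenyl ring carrying a carboxylic acid, would move the number beyond the scatter.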